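Trifluoromethyl on the Phenyl Group of Compound 2

A few compounds are considered here, and "the series" means these few. Any claim that something is new, unique, unknown or untested is made for them only; others in the source may bear on it.

Compound 1 `C=C(C)C(=O)c1ccc(OCc2nc(-c3ccccc3)no2)cc1C` and compound 2 `C=C(C)C(=O)c1ccc(OCc2nc(-c3ccccc3)no2)c(C)c1C` share one core. In an assay on HL-60 cells for inhibition of glutathione S-transferase P (Homo sapiens) (a higher number here means a weaker inhibitor, a lower number a stronger inhibitor), compound 1 gives 1970 nM, and compound 2 gives 1800 nM. Among the measured compounds shown here, the single step between them, a 1.1-fold lower number from compound 1 to compound 2 (0.04 log units; within the scatter), so compound 2 holds the lower of the two numbers only nominally, its gap to compound 1 lying within the scatter. Compound 3 `C=C(C)C(=O)c1ccc(OCc2nc(-c3ccc(C(F)(F)F)cc3)no2)c(C)c1C` differs from compound 2 by trifluoromethyl in place of hydrogen on an aromatic carbon. For the measured compounds named here, none of the measured steps touches the phenyl group; the only measured step concerns a methyl group on the core and was within the scatter. With nothing bearing on the new change, no step beyond the scatter is expected from compound 2 to compound 3, and the estimate means a 1.1-fold lower number from compound 2 to compound 3 (0.05 log units; within the scatter). Compound 3 is therefore estimated at 1600 nM, expected between 500 nM and 5000 nM.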

Compound 3, half-maximal inhibitory concentration: 3900 nM
Estimate against measurement, compound 3: 2.4-fold (0.39 log units) below; measured number inside the range.
By their numbers in this assay, from the lowest: compounds 2, 1 and 3 (each within the scatter of the next, the first and the last beyond it).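

In this assay the step from phenyl to 4-(trifluoromethyl)phenyl gives a 2.2-fold higher number from compound 2 to compound 3 (0.34 log units; beyond the scatter) and is the only step among these compounds to pass the scatter, a modest one, unlike the methyl step a 1.1-fold lower number from compound 1 to compound 2 (0.04 log units; within the scatter) on the core. It shows that the number can respond to a change on this phenyl group, at the aromatic carbon para to a large group, and that here the response is toward a weaker inhibitor. Nothing at hand explains this step.

The compounds shown leave open whether the change follows from trifluoromethyl itself or would also appear with another group at this carbon, such as a fluorine atom, a methoxy group, an amine or a carboxylic acid. They also leave open how trifluoromethyl would read on another carbon of this phenyl group.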